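Series notes: permeability step from compound 2 to compound 3

The source may hold more compounds than are shown below. What is called first, only, known or untested is meant among the compounds shown, and "the series" means these compounds.

Measured so far in an ADME assay for permeability, using PAMPA, at pH 7.4; on this read-out lower numbers stand for lower permeability and higher numbers for higher permeability:
- compound 1 `Cc1cc(NC(=O)Nc2ccc(C)c(Cl)c2)c2ccccc2n1`: 262 10^-6 cm/s
- compound 2 `Cc1cc(NC(=O)Nc2ncccc2C)c2ccccc2n1`: 369 10^-6 cm/s

Both measured compounds share the same core and differ only in the ring carried on the amide-type nitrogen. On the numbers shown, compound 2 gives the nominally higher of the two values, with compound 1 as its only neighbour; the gap between them lies within the usual scatter of repeated measurements, so the two cannot be separated with confidence.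

Compound 3 `Cc1cc(NC(=O)Nc2cccnc2)c2ccccc2n1` is not yet measured in this assay. Relative to compound 2 it carries the following change: pyridin-3-yl in place of 3-methylpyridin-2-yl on an amide-type nitrogen. No measured pair in the set isolates this change, so nothing shown here tells how large a step it brings.

Given that both measured compounds sit at high values in this assay and differ little from each other, compound 3 is expected to stay in the same region, with a step of a 1.2-fold lower number from compound 2 to compound 3 (0.09 log units; within the scatter) that is estimated to remain within the scatter. The value for compound 3 is estimated at 300 10^-6 cm/s, in a range from 150 10^-6 cm/s to 500 10^-6 cm/s.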

Compound 3, apparent permeability: 63 10^-6 cm/s
For compound 3 the middle estimate is 4.8-fold (0.68 log units) above the measured one, and the stated range ends above it.
By their numbers in this assay, from the lowest: compound 3; then compounds 1 and 2 (each within the scatter of the next).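

In this assay, for the compounds shown here, the ring on the amide-type nitrogen proves to matter: pyridin-3-yl in place of 3-methylpyridin-2-yl gives a 5.9-fold lower number from compound 2 to compound 3 (0.77 log units; beyond the scatter) and is the first step to lie beyond the scatter. Compound 1 and compound 2 could not be separated, so the earlier values gave no sign that this position could move the read-out; with compound 3 at 63 10^-6 cm/s it clearly can, even though the entering and leaving groups are both six-membered aromatic rings with the same counts of hydrogen-bond donors and acceptors. No measurement on hand accounts for the size of this step.

Two features change together in this single step, the methyl group and the point at which the pyridine ring is attached, so the compounds shown leave open which of the two goes with the lower number. Also open, from the compounds shown here alone, is whether a plain pyridin-2-yl, a 3-methylpyridin-4-yl or a ring carrying an amine on this nitrogen would give a value close to that of compound 2 or to that of compound 3.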